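The source may hold more compounds than are shown below. What is called first, only, known or untested is meant among the compounds shown, and "the series" means these compounds.

Measured in a functional assay on HepG2 cells (Homo sapiens) for cytotoxicity, read by MTT assay, with a stated time of 72 h; on this read-out higher numbers stand for weaker inhibition and lower numbers for stronger inhibition:

compound 1, `CN1CCN(CCCCOc2c(OCc3ccc(C#N)cc3)cc(O)c3c(=O)cc(-c4ccccc4)oc23)CC1` — 590 nM
compound 2, `CN1CCN(CCCCOc2c(OCc3cccs3)cc(O)c3c(=O)cc(-c4ccccc4)oc23)CC1` — 4560 nM
compound 3, `CN1CCN(CCCCOc2c(OCc3nc4ccccc4o3)cc(O)c3c(=O)cc(-c4ccccc4)oc23)CC1` — 4110 nM

Compound 3 stands second highest of these three numbers, close to compound 2 and far from compound 1, which gives the lowest number and therefore the strongest inhibition of the set. The compounds share one core and differ only in the group placed on a saturated chain carbon bound to an oxygen on an aromatic ring. Compound 4, `CN1CCN(CCCCOc2c(OCc3nc4ccccc4s3)cc(O)c3c(=O)cc(-c4ccccc4)oc23)CC1`, carries the change (1,3-benzothiazol-2-yl in place of 1,3-benzoxazol-2-yl on a saturated chain carbon bound to an oxygen on an aromatic ring). The steps measured so far speak to it only indirectly. Replacing 4-cyanophenyl by a different ring cost potency both times, a 7.7-fold higher number from compound 1 to compound 2 (0.89 log units; beyond the scatter) and a 7.0-fold higher number from compound 1 to compound 3 (0.84 log units; beyond the scatter), whereas exchanging one such ring for another left the number essentially unchanged, a 1.1-fold lower number from compound 2 to compound 3 (0.05 log units; within the scatter). Compound 4 keeps the two-ring shape of compound 3 and swaps one ring atom. On that basis, compound 4 is expected to stay close to compound 3, with a step of a 1.0-fold lower number from compound 3 to compound 4 (0.01 log units; within the scatter) in this assay. The estimate for compound 4 in this assay is 4000 nM, between 1500 nM and 11000 nM.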

Compound 4, half-maximal inhibitory concentration: 5440 nM
Compound 4: the middle estimate sits 1.4-fold (0.13 log units) below what was measured; the measured number falls inside the stated range.
By their numbers in this assay, from the lowest: compound 1; then compounds 3, 2 and 4 (each within the scatter of the next).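

In this assay, exchanging the oxygen of the 1,3-benzoxazol-2-yl group for the sulfur of 1,3-benzothiazol-2-yl gives no difference that can be told from scatter (a 1.3-fold higher number from compound 3 to compound 4 (0.12 log units; within the scatter)), and the same is true when compound 4 is set against the thiophen-2-yl compound (a 1.2-fold higher number from compound 2 to compound 4 (0.08 log units; within the scatter)). Compound 4 therefore lies well apart from the 4-cyanophenyl compound (a 9.2-fold higher number from compound 1 to compound 4 (0.96 log units; beyond the scatter)), as compound 2 and compound 3 do, so the lower number still belongs to compound 1 alone. No supporting measurement here explains this separation.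

The compounds shown leave open whether the nitrile or the benzene ring of 4-cyanophenyl matters more, a question that a plain phenyl group could address. A 4-methoxyphenyl or pyridin-3-yl group at this position also remains untested in what is shown.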